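Tetrazole Against Carboxy on a Shared Anilide Scaffold

A few compounds are considered here, and "the series" means these few. Any claim that something is new, unique, unknown or untested is made for them only; others in the source may bear on it.

Of the compounds shown here, three from this study have been tested in a functional assay on the whole organism with Rattus norvegicus as the target, at a dose of 25 mg/kg by the intravenous route; on this read-out higher numbers stand for an effect only at larger amounts of compound and lower numbers for an effect already at smaller amounts. Compound 1 `O=C(O)c1ccc(NC(=O)c2ccc(C(=O)O)cc2)cc1` gives 25.4 mg/kg in this assay. Compound 2 `O=C(O)c1ccc(NC(=O)c2ccc(-c3nn[nH]n3)cc2)cc1` gives 2.3 mg/kg in this assay. The two differ in one place, (carboxy in place of 2H-tetrazol-5-yl on an aromatic carbon), and this change makes a step of an 11-fold higher number from compound 2 to compound 1 (1.04 log units; beyond the scatter). Compound 3 `O=C(O)c1cc(NC(=O)c2ccc(-c3nn[nH]n3)cc2)cc(C(=O)O)c1` gives 1.2 mg/kg in this assay, a number that lies within the usual scatter of the value of compound 2, so no order between compound 3 and compound 2 is claimed; the difference between the cores of compound 3 and compound 2 is not broken down here. Compound 4 `O=C(O)c1ccc(C(=O)Nc2cc(C(=O)O)cc(C(=O)O)c2)cc1` has not yet been measured in this assay. It differs from compound 3 by carboxy in place of 2H-tetrazol-5-yl on an aromatic carbon, the same change as that from compound 2 to compound 1. Among the compounds with values here, for compound 4 a step of an 11-fold higher number from compound 3 to compound 4 (1.03 log units; beyond the scatter) is expected, beside the earlier 11-fold higher number from compound 2 to compound 1 (1.04 log units; beyond the scatter), because the only measured example of this change is the step of an 11-fold higher number from compound 2 to compound 1 (1.04 log units; beyond the scatter). Compound 4 is therefore estimated at 13 mg/kg, with a range from 5 mg/kg to 35 mg/kg expected.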

Compound 4, dose for 50% inhibition: 2.1 mg/kg
For compound 4 the middle estimate is 6.2-fold (0.79 log units) above the measured one; the measured number lies below the stated range.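

In this assay, putting carboxy in place of 2H-tetrazol-5-yl gives a 1.8-fold higher number from compound 3 to compound 4 (0.24 log units; within the scatter), so a change that made a large step on one core does not keep that size on the other. Set side by side, the two examples of the change disagree: the same change on two cores in this assay, an 11-fold higher number (1.04 log units; beyond the scatter) from compound 2 to compound 1 and a 1.8-fold higher number (0.24 log units; within the scatter) from compound 3 to compound 4, 6.3-fold (0.80 log units) apart, beyond the scatter of two such steps This shows that, in this series, the size of the step measured on one core cannot simply be carried over to another, but it does not show why the steps differ, and two examples give no rule for predicting the step on any further core.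

The compounds shown leave open which feature of the two cores governs the size of the step, since the difference between those cores is not broken down here. Going by these compounds, it also remains open how an amine or a sulfonic acid would read in this assay in the place held by 2H-tetrazol-5-yl, on either core.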